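The source may hold more compounds than are shown below. What is called first, only, known or untested is meant among the compounds shown, and "the series" means these compounds.

Working notes on the series in a functional assay (aorta) with Rattus norvegicus as the target; a higher number here means that more compound is needed for the effect, a lower number that less compound is needed.

Compound 1 `COc1ccc(-c2nc(N=C(N)N)sc2-c2ccc(OC)cc2)cc1` gives 2 uM in this assay. Among the compounds with values here, compound 2 `COc1ccc(-c2nc(CN(C)C)sc2-c2ccc(OC)cc2)cc1` gives 8.4 uM in this assay; it stands as the higher of the two numbers measured so far, and the only step known, a 4.2-fold higher number from compound 1 to compound 2 (0.62 log units; beyond the scatter), is a modest one that separates it from compound 1.

Compound 3 `COc1ccc(-c2nc(CNC(=O)CSC)sc2-c2ccc(OC)cc2)cc1` differs from compound 2 by (((methylsulfanyl)methyl)carbonyl)amino in place of dimethylamino on a saturated chain carbon bound to an aromatic carbon. Within the data shown here, no measured step concerns this kind of exchange: the single step in hand, a 4.2-fold higher number from compound 1 to compound 2 (0.62 log units; beyond the scatter), swaps one group of four heavy atoms for another on an aromatic carbon, whereas the change from compound 2 to compound 3 replaces dimethylamino with (((methylsulfanyl)methyl)carbonyl)amino on a saturated chain carbon bound to an aromatic carbon. The step from compound 1 to compound 2 therefore gives only a sense of scale, not of direction.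

With nothing pointing either way, the step from compound 2 to compound 3 is expected to be a 1.2-fold higher number from compound 2 to compound 3 (0.08 log units; within the scatter), no larger than the scatter. Compound 3 is accordingly estimated at 10 uM in this assay, with a range from 3 uM to 35 uM.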

Compound 3, concentration for half-maximal effect: 6 uM
Compound 3: the middle estimate sits 1.7-fold (0.22 log units) above what was measured; low and high end bracket the measured number.
By their numbers in this assay, from the lowest: compound 1; then compounds 3 and 2 (each within the scatter of the next).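

On the saturated chain carbon bound to an aromatic carbon, (((methylsulfanyl)methyl)carbonyl)amino in place of dimethylamino gives a 1.4-fold lower number from compound 2 to compound 3 (0.15 log units; within the scatter), so this assay does not separate these two groups, although the entering group has 1 hydrogen-bond donor where dimethylamino has 0. Within the data shown here, the group on the aromatic carbon in compound 1 stays apart from this second chain group too, with a 3.0-fold higher number from compound 1 to compound 3 (0.48 log units; beyond the scatter), so the separation from compound 1 now holds for two different chain groups, not only for the one in compound 2. Nothing at hand explains why the exchange on the chain carbon leaves the read-out within the scatter.

Open is whether this tolerance extends to a primary amine, a carboxylic acid or a longer alkyl chain on the same saturated chain carbon, since only dimethylamino and one amide-type group are shown there. Also open, on these data alone, is what the methylsulfanyl part contributes, which a simple acetyl amide or a methoxy in place of the methylsulfanyl would address.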